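Hydrazone aryl swap on the shared core

The compounds below may be only part of what the source reports. "The series", "measured", "known", "first", "only" and "open" are said of these compounds alone.

Compound 1 `CCCSc1nc(N/N=C/c2ccccc2F)c2nnn(Cc3ccccc3)c2n1` has only a limit in a functional assay on ECa-109 cells (Homo sapiens) for antiproliferative activity, read by MTT assay, with a stated time of 72 h; on this read-out higher numbers stand for weaker inhibition and lower numbers for stronger inhibition: compound 1 gives > 64000 nM, which is a limit of the assay and not a number. Compound 2 `CCCSc1nc(N/N=C(\C)c2ccccc2O)c2nnn(Cc3ccco3)c2n1` gives 5760 nM in this assay. Compound 3 `CCCSc1nc(N/N=C(\C)c2ccccc2O)c2nnn(Cc3ccccc3Cl)c2n1` sits at a limit in this assay, at > 64000 nM. Among the compounds with values here, the one measured step, an at least 11-fold higher number from compound 2 to compound 3 (1.04 log units; beyond the scatter), changes a different position and so bears only loosely on the step to compound 4 `CCCSc1nc(N/N=C/c2ccc3ccccc3c2)c2nnn(Cc3ccccc3)c2n1`, which carries naphthalen-2-yl in place of 2-fluorophenyl on a carbon with a double bond to nitrogen. Because the limit of > 64000 nM in this assay, at which 2 of the 3 values shown sit, marks where compound 1 sits, the size of the step from compound 1 cannot be fixed from the numbers shown. Compound 4 is expected near the same limit, estimated at 45000 nM with a range of 9000 nM to 64000 nM; the expected step is an at least 1.4-fold lower number from compound 1 to compound 4 (0.15 log units; that floor lies within the scatter).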

Compound 4, half-maximal inhibitory concentration: > 64000 nM
Compound 4 ended at the assay's limit; the forecaster's own chance of this, stated with the estimate: 60%; middle value at least 1.4-fold (0.15 log units) from the limit.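

No step can be read between compound 1 and compound 4 because both compounds sit at the same assay limit: the limit of > 64000 nM in this assay, at which 3 of the 4 values shown sit.

From the compounds shown here alone, how naphthalen-2-yl and 2-fluorophenyl compare on the shared core in this assay stays open.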